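Swapping a benzylamide for a methyl ester on a shared core

A few compounds are considered here, and "the series" means these few. Any claim that something is new, unique, unknown or untested is made for them only; others in the source may bear on it.

Three compounds share one core, and they differ only in the group attached to a carbonyl carbon. Compound 1 `N[C@H]1CC[C@H](Nc2c(C(=O)NCc3ccc(Cl)cc3)nc(Br)c3cccnc23)CC1` has not been tested: in a functional assay on MCF7 cells (Homo sapiens) for cytotoxicity, read by MTT assay, with a stated time of 72 h (a lower number here means a stronger inhibitor, a higher number a weaker inhibitor), compound 1 gives "not determined" (no result reported), so no single number describes where it stands. Compound 2 `N[C@H]1CC[C@H](Nc2c(C(=O)NCc3ccc(Oc4ccccc4)cc3)nc(Br)c3cccnc23)CC1` is the only measured point; in this assay compound 2 gives 7900 nM, which is a modest level of activity. Compound 3 `COC(=O)c1nc(Br)c2cccnc2c1N[C@H]1CC[C@H](N)CC1` has not yet been measured. It differs from compound 1 in one place: methoxy in place of (4-chlorobenzyl)amino on a carbonyl carbon. The benzyl amide with its ring and its hydrogen-bond donor is lost, and a small methoxy group takes its place. Among the measured compounds shown here, with no measured step between compounds to lean on, the expectation rests on the only recorded value, that of compound 2, and on the size of what leaves. The step from compound 1 to compound 3 is expected to go toward weaker inhibition in this assay, probably by more than the usual scatter. Compound 3 is therefore estimated to reach 25000 nM in this assay, within a range of 6000 nM to 100000 nM.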

Compound 3, half-maximal inhibitory concentration: > 20000 nM
Compound 3 ended at the assay's limit; the forecaster's own chance of this, stated with the estimate: 35%; the middle value lies beyond the limit too.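

Among the compounds shown here, no step from compound 1 to compound 3 can be read in this assay, where compound 1 gives "not determined" (no result reported) as its entry. Compound 3 stands at a limit of the assay, not at a number: the limit of > 20000 nM in this assay, at which 1 of the 3 values shown sits. What the compounds shown leave open is how far methoxy in place of (4-chlorobenzyl)amino on the carbonyl carbon shifts activity in this assay by itself.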